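The source may report more compounds than this note shows. Statements on the series, on what has been measured and on what is new or still open speak of the compounds shown alone.

Measured compounds:
Compound 1 `Cc1n[nH]c(-c2ccccc2NCC2=NCCN2)n1` gives < 5020 nM in an in vitro functional assay on cells (Fibroblast) for agonist activity at Alpha-1B adrenergic receptor (Homo sapiens) (a lower number here means that less compound is needed, a higher number that more compound is needed for the effect), a limit of the assay rather than a number.
Compound 2 `Cn1ccc(-c2ccccc2NCC2=NCCN2)n1` gives 50.1 nM in this assay.
Compound 3 `Cn1ncnc1-c1ccccc1NCC1=NCCN1` gives 39.8 nM in this assay.

Compound 3 holds the lowest of the two numbers; the nearest is compound 2, with the step of a 1.3-fold lower number from compound 2 to compound 3 (0.10 log units; within the scatter), so the two cannot be put in order. Compound 1 sits at the limit (the limit of < 5020 nM in this assay, at which 1 of the 3 values shown sits), and the steps a step that the limit leaves unreadable from compound 1 to compound 2 and a step that the limit leaves unreadable from compound 1 to compound 3 are therefore not readable in size.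

Compound 4 `Cn1ccnc1-c1ccccc1NCC1=NCCN1` is to be measured in this assay. It differs from compound 3 as follows: 1-methyl-1H-imidazol-2-yl in place of 1-methyl-1H-1,2,4-triazol-5-yl on an aromatic carbon. Going by the values given here, the only measured step that bears on this change is the exchange of one methyl-bearing five-membered aromatic ring for another between compound 2 and compound 3, a 1.3-fold lower number from compound 2 to compound 3 (0.10 log units; within the scatter), which stayed within the scatter. The exchange of 1-methyl-1H-1,2,4-triazol-5-yl for 1-methyl-1H-imidazol-2-yl is a change of the same kind, so no step beyond the scatter is expected in this assay in either direction. Compound 4 is expected at 45 nM, between 15 nM and 150 nM, which means an expected 1.1-fold higher number from compound 3 to compound 4 (0.05 log units; within the scatter).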

Compound 4, half-maximal effective concentration: 39.8 nM
Compound 4: the middle estimate sits 1.1-fold (0.05 log units) above what was measured, and the stated range covers the measured number.
By their numbers in this assay, from the lowest: compounds 3, 4 and 2 (each within the scatter of the next).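

At this place, on an aromatic carbon of a six-membered aromatic ring of carbon only, 1-methyl-1H-imidazol-2-yl stands in for 1-methyl-1H-1,2,4-triazol-5-yl in this assay with no change at the digits printed from compound 3 to compound 4 (within the scatter), and against 1-methyl-1H-pyrazol-3-yl the record is a 1.3-fold lower number from compound 2 to compound 4 (0.10 log units; within the scatter). Going from 3 to 2 hetero atoms and from 3 to 2 hydrogen-bond acceptors in this ring therefore leaves the number within the scatter, so the three rings of compound 2, compound 3 and compound 4 cannot be put in order. The steps from compound 1, including the one to compound 4, cannot be read, and its value remains a limit of the assay: the limit of < 5020 nM in this assay, at which 1 of the 4 values shown sits.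

From the compounds shown here alone, what separates compound 1 from the other three remains open. Also open, going by these compounds, is how the number responds when an ethyl or a phenyl replaces the methyl on the ring, or when a carboxylic acid or an amine stands at this place.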